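This account rests on a few compounds, and the source may have more. Where it says the series, first, only, none or still open, it means among the compounds named here.

Compound 1 `CN1CCC[C@H]1[C@@H]1COc2cc(N)ccc2O1` stands as the lower of the two numbers in an assay on membranes from HEK293 cells for displacement of a labelled ligand from Neuronal acetylcholine receptor; alpha3/beta4 (Homo sapiens), with a stated time of 5 min (a lower number here means a stronger inhibitor, a higher number a weaker inhibitor), giving 3500 nM. Its partner compound 2 `CN1CCC[C@H]1[C@H]1COc2cc(N)ccc2O1` gives 8600 nM, and the step of a 2.5-fold higher number from compound 1 to compound 2 (0.39 log units; beyond the scatter) rests on (the fact that compounds 1 and 2 differ only in the configuration as drawn). The unmeasured compound 3 `CN1CCC[C@H]1[C@@H]1COc2cc([N+](=O)[O-])ccc2O1` differs from compound 1 in one place: nitro in place of amino on an aromatic carbon. Among the measured compounds shown here, no measured step touches this aromatic substituent; the one step known in this assay concerns only a stereocentre on the saturated ring, so it offers no direct guide to a swap of amino for nitro. On that basis the change is expected to move the number only modestly, with no firm direction, and a small weakening is taken as the more likely outcome, giving an expected step of a 1.4-fold higher number from compound 1 to compound 3 (0.15 log units; within the scatter). Compound 3 is therefore estimated at 5000 nM in this assay, within a range from 1500 nM to 20000 nM.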

Compound 3, inhibition constant: 15000 nM
Compound 3: middle estimate off by 3.0-fold (0.48 log units), on the low side, and the stated range covers the measured number.
By their numbers in this assay, from the lowest: compound 1; then compounds 2 and 3 (each within the scatter of the next).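

Nitro in place of amino on the aromatic carbon gives a 4.3-fold higher number from compound 1 to compound 3 (0.63 log units; beyond the scatter) in this assay, so this substituent position does affect the number, and of the two groups amino gives the lower one. The earlier step concerned only a stereocentre on the saturated ring and showed nothing about the aromatic ring of the shared core. The evidence at hand offers no account of why this swap moves the number.

The compounds shown leave open whether a hydroxyl, a methoxy group or an acetamide on the same carbon would stand closer to amino or to nitro, and what a bare hydrogen there would give. They also leave open whether the same swap would move the number as far in the configuration of compound 2.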